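Shifting a Chlorine on a Pair with Low Inhibition Numbers

This account rests on a few compounds, and the source may have more. Where it says the series, first, only, none or still open, it means among the compounds named here.

Measured so far:
Compound 1, `O=C(N/N=C/c1cccc(Cl)c1)c1ccc(O[C@@H]2O[C@H](CO)[C@@H](O)[C@H](O)[C@H]2O)cc1`, gives 5.02% in a functional assay on MDA-MB-231 cells (Homo sapiens) for inhibition, read by MTT assay, with a stated time of 24 h, tested at 100 uM; a higher number here means more inhibition at the concentration tested (going by the name of the read-out), a lower number less inhibition.
Compound 2, `CC(C)/C=N/NC(=O)c1ccc(O[C@@H]2O[C@H](CO)[C@@H](O)[C@H](O)[C@H]2O)cc1`, gives 1.7% in this assay.

Compound 1 holds the highest of these two numbers, with compound 2 nearest: a number 3.3 percentage points lower from compound 1 to compound 2 (within the scatter). Compound 3, `O=C(N/N=C/c1ccc(Cl)cc1)c1ccc(O[C@@H]2O[C@H](CO)[C@@H](O)[C@H](O)[C@H]2O)cc1`, differs from compound 1 by 4-chlorophenyl in place of 3-chlorophenyl on a carbon with a double bond to nitrogen. For the measured compounds named here, the single measured step replaced the whole aromatic group and still stayed within the scatter, so no measured step bears directly on moving the chlorine; both numbers sit near the bottom of the scale. Compound 3 is therefore expected to show no step beyond the scatter, a number 0 percentage points lower from compound 1 to compound 3 (within the scatter). Compound 3 is estimated at 5%, between 0% and 15%.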

Compound 3, a percentage reported as inhibition, at one concentration (the size of the read-out at that concentration, not a potency): 2.26%
Compound 3: the middle estimate sits 2.7 percentage points above what was measured; measured number inside the range.
By their numbers in this assay, from the lowest: compounds 2, 3 and 1 (each within the scatter of the next).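

Moving the chlorine, with 4-chlorophenyl in place of 3-chlorophenyl, gives a number 2.8 percentage points lower from compound 1 to compound 3 (within the scatter). Putting 4-chlorophenyl in place of isopropyl gives a number 0.6 percentage points higher from compound 2 to compound 3 (within the scatter), so neither change separates these compounds in this assay. Nothing available explains these numbers.

As far as these compounds go, it remains open whether any other group on this carbon would give a number beyond the scatter, such as a phenyl ring carrying an amine or a carboxylic acid. A longer chain in place of isopropyl is also an open case.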